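This account rests on a few compounds, and the source may have more. Where it says the series, first, only, none or still open, it means among the compounds named here.

Compound 1 `NC1=NN(c2ccccc2)C(=O)/C1=C/Nc1ccc(S(=O)(=O)Nc2ccccn2)cc1` was tested in a functional assay on HepG2 cells (Homo sapiens) for cytotoxicity, tested at 40 uM; on this read-out lower numbers stand for a weaker effect and higher numbers for a stronger effect at the one concentration tested. In this assay compound 1 gives 80.2%. Two related compounds built on different cores were run alongside it: compound 2 `Cc1cc(C)nc(NS(=O)(=O)c2ccc(N/C=C3/C(=N)N(c4ccccc4)N=C3N)cc2)n1` gives 80.7%, and compound 3 `N=C1NN=C(N)/C1=C\Nc1ccc(S(=O)(=O)Nc2cnc3ccccc3n2)cc1` gives 85.8%. All three numbers lie within the usual scatter of one another, so compound 1 stands together with the other two rather than apart from them; no difference among them can be claimed.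

Compound 4 `NC1=NN(c2ccccc2)C(=O)/C1=C/Nc1ccc(S(=O)(=O)Nc2cnc3ccccc3n2)cc1` keeps the core of compound 1 and changes only the group on the sulfonamide nitrogen: quinoxalin-2-yl in place of pyridin-2-yl on a sulfonamide nitrogen. Among the compounds with values here, no step between two measured compounds isolates this exchange. Compound 3 also carries the quinoxalin-2-yl group on its sulfonamide nitrogen, yet its core differs from that of compound 1. Compound 1 gives 80.2% and compound 3 gives 85.8%, and the two values only show that both sit in the same narrow band.

On this basis the step from compound 1 to compound 4 is expected to be small, at most a slight rise, and not clearly beyond the scatter, as a number 2.8 percentage points higher from compound 1 to compound 4 (within the scatter). For compound 4 a value of 83% is therefore estimated, in the range from 70% to 93%.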

Compound 4, a percentage reported as activity, at one concentration (the size of the read-out at that concentration, not a potency): 79.4%
The estimate for compound 4 lay 3.6 percentage points above the measured number, and the stated range covers the measured number.
By their numbers in this assay, from the lowest: compounds 4, 1, 2 and 3 (each within the scatter of the next).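

Within the data shown here, this is the first step that isolates the group on the sulfonamide nitrogen: on the core of compound 1, quinoxalin-2-yl in place of pyridin-2-yl gives a number 0.8 percentage points lower from compound 1 to compound 4 (within the scatter) in this assay at the one concentration tested. Among these compounds, at this position, therefore, a group of 10 heavy atoms with two aromatic rings can replace a single aromatic ring of 6 heavy atoms without a change in the read-out that stands clear of the scatter, which the earlier comparisons across different cores could not show. Nothing measured here gives a reason for this outcome.

On these data alone, both groups compared at this place are aromatic rings, so it remains open whether a non-aromatic group on the sulfonamide nitrogen, such as a methyl group, a longer alkyl chain or a chain ending in a carboxylic acid, would leave the read-out equally unchanged. As far as these compounds go, it also remains open whether the same exchange would behave alike on the other cores, or whether compound 1 and compound 4 would separate at lower concentrations, since a single-concentration read-out is not a potency.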